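Amide variation on a hexafluoro-carbinol naphthylamine core

The source may hold more compounds than are shown below. What is called first, only, known or untested is meant among the compounds shown, and "the series" means these compounds.

Measured so far:
- compound 1 `CC(C)=CC(=O)Nc1c(C(O)(C(F)(F)F)C(F)(F)F)ccc2ccccc12`: 550 nM
- compound 2 `O=C(Nc1c(C(O)(C(F)(F)F)C(F)(F)F)ccc2ccccc12)C1CC1`: 126 nM
- compound 3 `COCC(=O)Nc1c(C(O)(C(F)(F)F)C(F)(F)F)ccc2ccccc12`: 204 nM

In a functional assay (Sus scrofa) with sulfonylurea receptors; K-ATP channels (Homo sapiens) as the target (a higher number here means that more compound is needed for the effect, a lower number that less compound is needed), compound 3 gives the second highest of the three numbers; a 1.6-fold higher number from compound 2 to compound 3 (0.21 log units; within the scatter), while a 2.7-fold lower number from compound 1 to compound 3 (0.43 log units; beyond the scatter). Compound 4 `O=C(Nc1c(C(O)(C(F)(F)F)C(F)(F)F)ccc2ccccc12)c1cccc(Cl)c1` carries 3-chlorophenyl in place of methoxymethyl on a carbonyl carbon. Within the data shown here, no measured step places an aromatic ring on this carbonyl carbon, so none bears on the change directly. Among the measured compounds shown here, the three known steps, a 4.4-fold lower number from compound 1 to compound 2 (0.64 log units; beyond the scatter), a 2.7-fold lower number from compound 1 to compound 3 (0.43 log units; beyond the scatter) and a 1.6-fold higher number from compound 2 to compound 3 (0.21 log units; within the scatter), show only modest movement across the acyl groups tried, with no pair differing greatly. On that basis a small step is expected, direction uncertain, and a 1.1-fold higher number from compound 3 to compound 4 (0.03 log units; within the scatter) is taken as roughly level. For compound 4 the estimate in this assay is 220 nM, with a range from 60 nM to 800 nM.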

Compound 4, half-maximal effective concentration: 851 nM
The estimate for compound 4 lay 3.9-fold (0.59 log units) below the measured number; the measured number lies above the stated range.
By their numbers in this assay, from the lowest: compounds 2 and 3 (each within the scatter of the next); then compounds 1 and 4 (each within the scatter of the next).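

In this assay, 3-chlorophenyl, the first aromatic ring on this carbonyl carbon, gives a 4.2-fold higher number from compound 3 to compound 4 (0.62 log units; beyond the scatter) and a 6.8-fold higher number from compound 2 to compound 4 (0.83 log units; beyond the scatter), so it does not match methoxymethyl or cyclopropyl here. Against 2-methylprop-1-en-1-yl the same ring gives a 1.5-fold higher number from compound 1 to compound 4 (0.19 log units; within the scatter), which splits the four acyl groups into two tiers: compounds 2 and 3 with the lower numbers, compounds 1 and 4 with the higher. Nothing available accounts for this split.

From the compounds shown here alone, whether the higher number follows the ring or the chlorine stays open; a plain phenyl on this carbonyl carbon would separate the two. Going by these compounds, how an amine or a carboxylic acid in the acyl group would read also remains open.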